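The compounds below may be only part of what the source reports. "The series", "measured", "known", "first", "only" and "open" are said of these compounds alone.

Compound 1 `CCC(C)(C)Cc1c[nH]c(CCc2ccc(-c3cccc(N)n3)cc2)n1` is the reference point of this small set. In a functional assay on HEK293 cells for agonist activity at Bombesin receptor subtype-3 (Homo sapiens), read by luminescence and calcium flux, with a stated time of 10 min (a higher number here means that more compound is needed for the effect, a lower number that less compound is needed), compound 1 gives 37 nM, the lowest of the three numbers recorded; compound 2 `CCC(C)(C)Cc1c[nH]c(CCc2ccc(N3CCCCC3)cc2)n1` gives 171 nM and compound 3 `CCC(C)(C)Cc1c[nH]c(CCc2ccc(-n3ccnn3)cc2)n1` gives 641 nM. The step of a 4.6-fold higher number from compound 1 to compound 2 (0.66 log units; beyond the scatter) is modest, the step of a 17-fold higher number from compound 1 to compound 3 (1.24 log units; beyond the scatter) is large, and the step of a 3.7-fold higher number from compound 2 to compound 3 (0.57 log units; beyond the scatter) is modest, so every replacement of the 6-aminopyridin-2-yl group seen so far has raised the number in this assay.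

Compound 4 `CCC(C)(C)Cc1c[nH]c(CCc2ccc(-n3cncn3)cc2)n1` has not yet been measured. It differs from compound 1 in one place: 1H-1,2,4-triazol-1-yl in place of 6-aminopyridin-2-yl on an aromatic carbon. Among the compounds with values here, the closest precedent is compound 3, whose 1H-1,2,3-triazol-1-yl group also brings a five-membered aromatic ring with 3 hetero atoms and no hydrogen-bond donor to the same aromatic carbon, and compound 3 sits far from compound 1 because of a 17-fold higher number from compound 1 to compound 3 (1.24 log units; beyond the scatter). Compound 2 points the same way by a 4.6-fold higher number from compound 1 to compound 2 (0.66 log units; beyond the scatter).

Compound 4 is therefore expected to move a large step toward a higher number in this assay, roughly a 14-fold higher number from compound 1 to compound 4 (1.13 log units; beyond the scatter). The estimate for compound 4 in this assay is 500 nM, with a range from 200 nM to 1500 nM.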

Compound 4, half-maximal effective concentration: 570 nM
The estimate for compound 4 lay 1.1-fold (0.06 log units) below the measured number, and the stated range covers the measured number.
By their numbers in this assay, from the lowest: compound 1; then compound 2; then compounds 4 and 3 (each within the scatter of the next).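

In this assay the exchange of 1H-1,2,3-triazol-1-yl for 1H-1,2,4-triazol-1-yl on this aromatic carbon, para to a large group, leaves the number within the scatter (a 1.1-fold lower number from compound 3 to compound 4 (0.05 log units; within the scatter)). The large rise seen against the 6-aminopyridin-2-yl group is therefore not confined to a single triazole isomer (a 15-fold higher number from compound 1 to compound 4 (1.19 log units; beyond the scatter)), and the piperidin-1-yl group also keeps a modest distance from this second triazole (a 3.3-fold higher number from compound 2 to compound 4 (0.52 log units; beyond the scatter)). Nothing available explains why these groups differ.

The compounds shown do not separate the amine of the 6-aminopyridin-2-yl group from its six-membered aromatic ring, as that group differs from both triazoles in ring size and in hydrogen-bond donors at once. A pyridin-2-yl group without the amine, a plain phenyl group, or a 3-aminopyridine-type ring carrying its amine elsewhere would show whether the low number follows the amine, the ring, or the two together.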